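Swapping the triazole side chain on a shared core

The source may report more compounds than this note shows. Statements on the series, on what has been measured and on what is new or still open speak of the compounds shown alone.

Measured in a functional assay on A549 cells (Homo sapiens) for cytotoxicity, read by MTT assay, with a stated time of 72 h; on this read-out lower numbers stand for stronger inhibition and higher numbers for weaker inhibition:
- Compound 1 `O=C1c2c[n+]([O-])c3ccccc3c2C(=O)c2c1c1ccccc1n2Cc1cn(C[C@H](O)CO)nn1`: 1030 nM
- Compound 2 `O=C1c2c[n+]([O-])c3ccccc3c2C(=O)c2c1c1ccccc1n2CCCCN1CCCCC1`: 150 nM
- Compound 3 `O=C1c2c[n+]([O-])c3ccccc3c2C(=O)c2c1c1ccccc1n2Cc1cn(C[C@@H](O)CO)nn1`: 390 nM

Compound 3 stands in the middle of the three numbers, with compound 2 lower and compound 1 higher. The next compound, compound 4 `CN1CCN(CCCCCn2c3c(c4ccccc42)C(=O)c2c[n+]([O-])c4ccccc4c2C3=O)CC1`, changes the group on a saturated chain carbon bound to an aromatic nitrogen: 4-(4-methylpiperazin-1-yl)butyl in place of 1-(2,3-dihydroxypropyl)-1H-1,2,3-triazol-4-yl on a saturated chain carbon bound to an aromatic nitrogen. The closest measured comparison is a 2.6-fold higher number from compound 2 to compound 3 (0.41 log units; beyond the scatter), and it runs in the opposite direction. Compound 2 likewise carries a chain ending in a non-aromatic ring instead of the triazole. The same kind of exchange gave a 6.9-fold lower number from compound 1 to compound 2 (0.84 log units; beyond the scatter). The third step, a 2.6-fold lower number from compound 1 to compound 3 (0.42 log units; beyond the scatter), comes with the fact that compounds 1 and 3 differ only in the configuration as drawn, so the size of the exchange depends on which triazole compound is the reference. Compound 4 is therefore expected to give a lower number than compound 3, by a modest margin. The expected change is a 2.0-fold lower number from compound 3 to compound 4 (0.29 log units; within the scatter). For compound 4 the estimated value is 200 nM, with an expected range of 70 nM to 550 nM.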

Compound 4, half-maximal inhibitory concentration: 870 nM
The estimate for compound 4 lay 4.4-fold (0.64 log units) below the measured number; measured number outside the range, above it.
By their numbers in this assay, from the lowest: compound 2; then compound 3; then compounds 4 and 1 (each within the scatter of the next).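

In this assay, replacing the triazole with a chain ending in a non-aromatic ring does not by itself give a lower number: a 2.2-fold higher number from compound 3 to compound 4 (0.35 log units; beyond the scatter). Against the other triazole compound, the same exchange gives a 1.2-fold lower number from compound 1 to compound 4 (0.07 log units; within the scatter), so its reading depends on the reference, and the two references are set apart by one thing alone: the fact that compounds 1 and 3 differ only in the configuration as drawn. The largest new step, a 5.8-fold higher number from compound 2 to compound 4 (0.76 log units; beyond the scatter), separates two compounds without the triazole, so at this place the outcome depends on the particular chain and ring rather than on the loss of the triazole alone.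

The compounds shown leave open whether the ring or the chain length accounts for that step, as both change together. A pentyl chain ending in piperidin-1-yl, or a butyl chain ending in 4-methylpiperazin-1-yl, would separate the two.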